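A few compounds are considered here, and "the series" means these few. Any claim that something is new, unique, unknown or untested is made for them only; others in the source may bear on it.

Measured compounds:
compound 1 `CCCCCCCCCCCOC(=O)[C@H](N)CCC(=O)NC(CCCC(N)C(=O)O)C(=O)O`, in a functional assay on HEK293 cells for agonist activity at Nucleotide-binding oligomerization domain-containing protein 1 (Homo sapiens), read by spectrophotometry (a lower number here means that less compound is needed, a higher number that more compound is needed for the effect), compound 1 gives 0.066 nM
compound 2 `CCCCCCCCCCCOC(=O)[C@@H](CCC(=O)NC(CCCC(N)C(=O)O)C(=O)O)NC(=N)N`, in this assay compound 2 gives 0.238 nM

Compound 2 has the highest of the two numbers in this assay; its nearest neighbour is compound 1, and the step of a 3.6-fold higher number from compound 1 to compound 2 (0.56 log units; beyond the scatter) lies beyond the scatter. That step exchanged a hydrogen on the amine nitrogen of compound 1 for a group of 3 heavy atoms (1 carbon, 2 nitrogen; no ring).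

Compound 3 `CCCCCCCCCCCOC(=O)CCCC(=O)NC(CCCC(N)C(=O)O)C(=O)O` is not yet measured. It differs from compound 2 by a hydrogen atom in place of a group of 4 heavy atoms (1 carbon, 3 nitrogen; no ring), on a saturated chain carbon bound to a carbonyl carbon and a saturated chain carbon, so the whole nitrogen-bearing group at that chain carbon is gone rather than altered. For the measured compounds named here, only the step from compound 1 to compound 2 touches this position, and it gave a modest rise in the number; there is no step showing what complete removal does, so the direction rests on a single precedent. A further rise in this assay is expected for compound 3, with wide uncertainty: the estimated step is a 3.4-fold higher number from compound 2 to compound 3 (0.53 log units; beyond the scatter). The estimate for compound 3 in this assay is 0.8 nM, with a range from 0.15 nM to 5 nM.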

Compound 3, half-maximal effective concentration: 0.39 nM
For compound 3 the middle estimate is 2.1-fold (0.31 log units) above the measured one; measured number inside the range.
By their numbers in this assay, from the lowest: compound 1; then compounds 2 and 3 (each within the scatter of the next).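

In this assay, a hydrogen in place of the group of 4 heavy atoms (1 carbon, 3 nitrogen) gives a 1.6-fold higher number from compound 2 to compound 3 (0.21 log units; within the scatter) and so leaves compound 2 and compound 3 unseparated: at this saturated chain carbon, bound to a carbonyl carbon and a saturated chain carbon, the substituted nitrogen group and plain hydrogen cannot be told apart by this read-out. Hydrogen in place of amino at the same carbon gives a 5.9-fold higher number from compound 1 to compound 3 (0.77 log units; beyond the scatter), and with a 3.6-fold higher number from compound 1 to compound 2 (0.56 log units; beyond the scatter) as the other printed step, compound 1 alone stands apart from the other two, so the difference in this small set lies with the unsubstituted amino group. No supporting data bear on the origin of this pattern.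

Going by these compounds, it remains open whether the separation requires an amine as such, or whether a hydroxyl group, a methylamino group or a carboxylic acid at this carbon would match compound 1 or fall with compound 2 and compound 3. Also open, on these data alone, is whether the same pattern would hold with a shorter or longer chain on the ester.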